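The compounds below may be only part of what the source reports. "The series", "measured", "known", "first", "only" and "open" are said of these compounds alone.

Compound 1, `C/C(=C\CC/C(C)=C/CC[C@@H]1[C@@]2(C)CCC(=O)C(C)(C)[C@H]2CC[C@@]1(C)O)CC/C=C(\C)C(=O)OCc1cn(-c2ccc(C(F)(F)F)cc2)nn1`: > 150000 nM
Compound 2, `C/C(=C\CC/C(C)=C/CC[C@@H]1[C@@]2(C)CCC(=O)C(C)(C)[C@H]2CC[C@@]1(C)O)CC/C=C(\C)C(=O)OCc1cn(-c2ccccc2Br)nn1`: > 150000 nM
Compound 3, `C/C(=C\CC/C(C)=C/CC[C@@H]1[C@@]2(C)CCC(=O)C(C)(C)[C@H]2CC[C@@]1(C)O)CC/C=C(\C)C(=O)OCc1cn(-c2ccccc2C)nn1`: > 150000 nM

Three compounds built on the shared core of compound 1 have been tested in a functional assay on A549 cells (Homo sapiens) for antiproliferative activity, read by MTT assay, with a stated time of 48 h; a lower number here means a stronger inhibitor, a higher number a weaker inhibitor. For compound 1 the value > 150000 nM is a limit of the assay, not a number. Compound 2 likewise returns only a limit, > 150000 nM. Compound 3 also stands at a limit, > 150000 nM. Where compound 1 stands in this assay is therefore known only as this limit, and so is the limit of > 150000 nM in this assay, at which 3 of the 3 values shown sit. Within the data shown here, because every value is a limit, a step that the two limits leave unreadable from compound 1 to compound 2, a step that the two limits leave unreadable from compound 1 to compound 3 and a step that the two limits leave unreadable from compound 2 to compound 3 cannot be read in either size or direction; they show only that no exchange of the aryl group on the triazole has yet brought a measurable number.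

Compound 4, `C/C(=C\CC/C(C)=C/CC[C@@H]1[C@@]2(C)CCC(=O)C(C)(C)[C@H]2CC[C@@]1(C)O)CC/C=C(\C)C(=O)OCc1cn(-c2ccc(Br)cc2)nn1`, is the next member of this set. Relative to compound 1 the change is bromo in place of trifluoromethyl on an aromatic carbon. None of the three measured steps gives a readable size, so nothing in the data points to a step out of the limit. Compound 1, compound 2 and compound 3 each sit at the limit, and compound 4 is expected to do the same, with a step that the limit leaves unreadable from compound 1 to compound 4 carrying no readable size. Compound 4 is therefore estimated at 200000 nM in this assay, within a range from 100000 nM to 600000 nM.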

Compound 4, half-maximal inhibitory concentration: > 150000 nM
Compound 4: only a limit was reported; the forecaster's own chance of this, stated with the estimate: 85%; the middle value is on the limit's open side.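

Compound 4 returns only a limit, so its steps to compound 1, compound 2 and compound 3 cannot be read in either size or direction. All four compounds stand at the same limit: the limit of > 150000 nM in this assay, at which 4 of the 4 values shown sit. The compounds shown leave open whether any exchange of the aryl group on the shared core can give a measurable number.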